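The compounds below may be only part of what the source reports. "The series", "measured", "known", "first", "only" and "open" are said of these compounds alone.

Compound 2 `CCOC(=O)C1=Cc2ccccc2OC1(OCc1cc(-c2ccc(Br)cc2)no1)C(F)(F)F` carries a 4-bromophenyl group on the shared core. In a functional assay on HeLa cells (Homo sapiens) for inhibition, read by MTT assay, with a stated time of 24 h (a lower number here means a stronger inhibitor, a higher number a weaker inhibitor), compound 2 gives 52300 nM, the higher of the two plain numbers shown here. Compound 3 `CCOC(=O)C1=Cc2ccccc2OC1(OCc1cn(CC(=O)Nc2ccccc2F)nn1)C(F)(F)F` gives 49900 nM, which lies within the scatter of the number for compound 2. Compound 1 `CCOC(=O)C1=Cc2ccccc2OC1(OCc1cc(-c2ccc(F)cc2F)no1)C(F)(F)F` reaches only a limit of this assay, > 150000 nM. Among the compounds with values here, the one measured step, an at least 2.8-fold lower number from compound 1 to compound 2 (0.45 log units; beyond the scatter), therefore rests on the limit of > 150000 nM in this assay, at which 1 of the 3 values shown sits, and its true size is not fixed. Compound 4 `CCOC(=O)C1=Cc2ccccc2OC1(OCc1cc(-c2ccc(F)cc2)no1)C(F)(F)F` differs from compound 2 by fluoro in place of bromo on an aromatic carbon. Going back toward fluorine reverses part of that step, so a rise is expected, though of uncertain size. Compound 4 is expected to give 100000 nM in this assay, between 40000 nM and 200000 nM. This expectation means a 1.9-fold higher number from compound 2 to compound 4 (0.28 log units; within the scatter).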

Compound 4, half-maximal inhibitory concentration: 42300 nM
Compound 4: middle estimate off by 2.4-fold (0.37 log units), on the high side; low and high end bracket the measured number.
By their numbers in this assay, from the lowest: compounds 4, 3 and 2 (each within the scatter of the next). At a limit, above all of these: compound 1.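

In this assay the swap at this place, para to a large group, gives a 1.2-fold lower number from compound 2 to compound 4 (0.09 log units; within the scatter) and so bromo and fluoro cannot be told apart here. Hydrogen in place of one fluoro of the 2,4-difluorophenyl group gives an at least 3.5-fold lower number from compound 1 to compound 4 (0.54 log units; beyond the scatter) and this step, unlike the swap of bromo for fluoro, lies beyond the scatter. Its true size is not fixed, as it rests on a limit: the limit of > 150000 nM in this assay, at which 1 of the 4 values shown sits.

On these data alone, whether an amine or a carboxylic acid on this aromatic carbon would move the number beyond the scatter stays open.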